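The source may hold more compounds than are shown below. What is called first, only, known or untested is meant among the compounds shown, and "the series" means these compounds.

Three compounds share one core and were tested in an assay on HEK293 cells for inhibition of solute carrier family 12 member 2 (Homo sapiens), read by fluorescence, with a stated time of 30 min, tested at 100 uM; on this read-out higher numbers stand for a stronger effect at the one concentration tested and lower numbers for a weaker effect. Compound 1, `CCCCNc1ccc([N+](=O)[O-])cc1S(=O)(=O)NC`, gives 13.3%. Compound 2, `CCCCNc1ccc([N+](=O)[O-])cc1S(=O)(=O)N(C)C`, gives 15.2%, and compound 3, `CCCCCCNc1ccc([N+](=O)[O-])cc1S(=O)(=O)N(C)C`, gives 4.9%. Among these three numbers compound 2 stands highest, though its step from compound 1 is a number 1.9 percentage points higher from compound 1 to compound 2 (within the scatter), while its step to compound 3 is a number 10.3 percentage points lower from compound 2 to compound 3 (beyond the scatter).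

Compound 4 is `CCCCNc1ccc(C(=O)O)cc1S(=O)(=O)N(C)C`. It differs from compound 2 in one place: carboxy in place of nitro on an aromatic carbon.

Neither measured step touches this position. The step of a number 1.9 percentage points higher from compound 1 to compound 2 (within the scatter) concerns the sulfonamide nitrogen, and the step of a number 10.3 percentage points lower from compound 2 to compound 3 (beyond the scatter) concerns the saturated chain; both leave the nitro group unchanged. Within the data shown here, no measured pair therefore shows what exchanging the nitro group for a carboxy group does in this assay, and the expectation for compound 4 can rest only on the spread of the three measured values, all of which are low.

With that little to go on, the step expected from compound 2 to compound 4 in this assay is a number 6.8 percentage points higher from compound 2 to compound 4 (within the scatter), with a wide range. For compound 4 the estimated value in this assay is 22%, between 3% and 55%.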

Compound 4, a percentage reported as inhibition, at one concentration (the size of the read-out at that concentration, not a potency): 15.6%
Compound 4: middle estimate off by 6.4 percentage points, on the high side, within the range that was stated.
By their numbers in this assay, from the lowest: compounds 3, 1, 2 and 4 (each within the scatter of the next, the first and the last beyond it).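

In this assay, among these compounds, the exchange of nitro for carboxy on the aromatic carbon para to a butylamino group gives a number 0.4 percentage points higher from compound 2 to compound 4 (within the scatter) and is the first view of this position, which the earlier steps on the sulfonamide nitrogen and the saturated chain left untouched. At this one concentration the read-out does not separate the two groups, even though carboxy brings a hydrogen-bond donor that nitro lacks and has one hydrogen-bond acceptor where nitro has two. Nothing measured here offers a reason for this outcome.

On these data alone, what a nitrile, an amide or an amine would give on the same aromatic carbon remains open, so one exchange cannot show whether this position tolerates change in general or whether these two groups merely happen to give matching numbers. Also open, as far as these compounds go, is whether carboxy would match nitro on the longer chain of compound 3 or with the single methyl on the sulfonamide nitrogen of compound 1, and, with only one concentration tested, how the potencies of compound 2 and compound 4 compare.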